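Compound 4 and the limit of the cytotoxicity read-out

The source may report more compounds than this note shows. Statements on the series, on what has been measured and on what is new or still open speak of the compounds shown alone.

Measured so far in an ADME assay on H9c2 cells (Rattus norvegicus) for cytotoxicity (on this read-out lower numbers stand for stronger inhibition and higher numbers for weaker inhibition), each value being a limit:
Compound 1 `CCc1ccc2nc(NC(=O)C3CC3)sc2c1` gives > 50000 nM as its limit
Compound 2 `CCOc1ccc2nc(NC(=O)C3CC3)sc2c1` gives > 50000 nM as its limit
Compound 3 `CC(C)C(=O)Nc1nc2ccc(Cl)cc2s1` gives > 50000 nM as its limit

Going by the values given here, compound 3 therefore offers no number to start from, and the whole set shows the limit of > 50000 nM in this assay, at which 3 of the 3 values shown sit, as its only reading. Compound 4 `O=C(Nc1nc2ccc(Cl)cc2s1)C1COC1` carries oxetan-3-yl in place of isopropyl on a carbonyl carbon, counted as oxetan-3-yl in place of isopropyl on a carbonyl carbon with the rest unchanged. Among the compounds with values here, the one measured step, a step that the two limits leave unreadable from compound 1 to compound 2, lies at another place and offers no size to carry over. No change beyond the scatter is therefore expected in this assay, and the expected step is a step that the limit leaves unreadable from compound 3 to compound 4 in either direction. Compound 4 is estimated at 60000 nM, with an expected range from 30000 nM to 120000 nM and another limit as the likely report.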

Compound 4, half-maximal inhibitory concentration: > 50000 nM
Compound 4: only a limit was reported (the forecaster's own chance of this, stated with the estimate: 85%); the middle value is on the limit's open side.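

Compound 3 and compound 4 each report only a limit in this assay and no size can be read for the step between them. What stays open is how any compound shown would read beyond the one limit reported: the limit of > 50000 nM in this assay, at which 4 of the 4 values shown sit.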